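This account rests on a few compounds, and the source may have more. Where it says the series, first, only, none or still open, it means among the compounds named here.

Measured compounds:
compound 1, `COc1ccc(Oc2ccc3c(NCCCNCc4cccc(OC)c4O)ccnc3c2)cc1` — 9.28
compound 2, `CCC(CC)c1ccc2c(NCCCNCc3cccc(OC)c3O)ccnc2c1` — 9.47
compound 3, `COc1cccc(CNCCCNc2ccnc3cc(Cc4ccc(F)cc4)ccc23)c1O` — 9.47

In a physicochemical assay for acid dissociation, compound 3 gives 9.47, level with compound 2 and with it the highest of the three numbers. Its nearest neighbour is compound 2, no change at the digits printed from compound 2 to compound 3 (within the scatter); its furthest is compound 1, a number 0.19 log units higher from compound 1 to compound 3 (within the scatter). All three measured values lie within the scatter of one another.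

Compound 4, `COc1cccc(CNCCCNc2ccnc3cc(-c4ccc(F)cc4)ccc23)c1O`, differs from compound 3 in one place: 4-fluorophenyl in place of 4-fluorobenzyl on an aromatic carbon. The measured steps that bear on this change are the three that exchange the group on the same aromatic carbon of the shared core: a number 0.19 log units higher from compound 1 to compound 2 (within the scatter), a number 0.19 log units higher from compound 1 to compound 3 (within the scatter) and no change at the digits printed from compound 2 to compound 3 (within the scatter). None of them moved this assay beyond the scatter, although they exchanged groups that differ from one another far more than 4-fluorophenyl differs from 4-fluorobenzyl. No step beyond the scatter is therefore expected here, a number 0.02 log units lower from compound 3 to compound 4 (within the scatter). Compound 4 is estimated at 9.45 in this assay, with a range from 9.15 to 9.75.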

Compound 4, acid dissociation constant: 9.47
Beside the measured number, compound 4's estimate is 0.02 log units below it, and the stated range covers the measured number.
By their numbers in this assay, from the lowest: compounds 1, 2, 3 and 4 (each within the scatter of the next).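

In this assay, 4-fluorophenyl in place of 4-fluorobenzyl on this aromatic carbon, with 8 heavy atoms going to 7, gives no step beyond the scatter (no change at the digits printed from compound 3 to compound 4 (within the scatter)). The same holds against the other two groups (no change at the digits printed from compound 2 to compound 4 (within the scatter); a number 0.19 log units higher from compound 1 to compound 4 (within the scatter)), so the position now holds four groups within the scatter, and compound 4 adds the case of a carbon-only aromatic ring standing directly on the aromatic carbon. No measurement shown accounts for this flat reading.

From the compounds shown here alone, whether a carboxylic acid or an amine on this aromatic carbon would give a step beyond the scatter remains open. Also open, going by these compounds, are which proton of the shared core this number reports, and whether a longer chain between the two nitrogens would shift it.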